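The compounds below may be only part of what the source reports. "The series", "measured", "known", "first", "only" and "open" are said of these compounds alone.

Measured compounds:
Compound 1 `CCOc1ccc(C(=O)/C=C/c2ccc(N(C)C)cc2)cc1`: 210 nM
Compound 2 `CC/C(C)=N/Oc1ccc(C(=O)/C=C/c2ccccc2)cc1`: 86 nM
Compound 3 `O=C(/C=C/c1cccc(F)c1)c1ccc(-n2ccnc2)cc1`: > 10000 nM

In an assay on isolated protein for inhibition of Amine oxidase [flavin-containing] B (Homo sapiens) (a higher number here means a weaker inhibitor, a lower number a stronger inhibitor), compound 1 gives 210 nM, the higher of the two numbers recorded, and compound 2 gives 86 nM, a gap beyond the scatter. Compound 3 reaches only the limit (the limit of > 10000 nM in this assay, at which 1 of the 3 values shown sits), which is a limit of this assay and not a number. Compound 4 `CCOc1ccc(C(=O)/C=C/c2ccc(C(F)(F)F)cc2)cc1` has not yet been measured in this assay. It differs from compound 1 in one place: trifluoromethyl in place of dimethylamino on an aromatic carbon. Among the compounds with values here, no measured pair follows this change, so the direction is uncertain; a modest step toward a lower number is expected, a 2.1-fold lower number from compound 1 to compound 4 (0.32 log units; beyond the scatter). Compound 4 is accordingly estimated at 100 nM, with a range from 20 nM to 1000 nM.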

Compound 4, half-maximal inhibitory concentration: 210 nM
Compound 4: middle estimate off by 2.1-fold (0.32 log units), on the low side, within the range that was stated.
By their numbers in this assay, from the lowest: compound 2; then compounds 1 and 4 (each within the scatter of the next). At a limit, above all of these: compound 3.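

Trifluoromethyl in place of dimethylamino, on an aromatic carbon para to a large group, gives no change at the digits printed from compound 1 to compound 4 (within the scatter) in this assay. At this position, then, the exchange of a group counted with a hydrogen-bond acceptor for one counted without any leaves the reading unmoved in this single pair. Nothing measured here accounts for the two groups reading alike.

Going by these compounds, whether other groups at this position would read the same stays open, for instance a carboxylic acid, a primary amine or a methoxy group. One pair sets no trend for this position.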